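Shortening an ethyl group to methyl: a solubility estimate

This account rests on a few compounds, and the source may have more. Where it says the series, first, only, none or still open, it means among the compounds named here.

Compound 1 `CCc1ccc(-c2nc3c(c(C)nn3-c3ccccc3)c(-c3ccccc3O)c2C#N)cc1`: 3100 nM
Compound 2 `CCc1ccc(-c2nc3c(c(C)nn3-c3ccccc3)c(-c3ccccc3I)c2C#N)cc1`: 8500 nM

In a physicochemical assay for solubility, read by spectrophotometry, in phosphate buffer, with a stated time of 18 h, at pH 7.4 (on this read-out higher numbers stand for higher solubility and lower numbers for lower solubility), compound 1 holds the lower of the two numbers at 3100 nM, while compound 2 stands higher at 8500 nM. Compound 3 `Cc1ccc(-c2nc3c(c(C)nn3-c3ccccc3)c(-c3ccccc3O)c2C#N)cc1` has not yet been measured. It keeps the core of compound 1 and its hydroxy group, but 4-ethylphenyl becomes 4-methylphenyl: hydrogen in place of methyl on a saturated chain carbon bound to an aromatic carbon. In other words, hydrogen comes in place of methyl on a saturated chain carbon bound to an aromatic carbon.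

For the measured compounds named here, only one measured step exists, a 2.7-fold higher number from compound 1 to compound 2 (0.44 log units; beyond the scatter). It concerns a different change, iodo in place of hydroxy on an aromatic carbon, so it bears on this question only indirectly. It shows the size a single replacement reached here, and that size was modest. Going by the values given here, no measured pair shows ethyl going to methyl, so the direction stays open, and no shift beyond the scatter is expected in this assay. The expected change is a 1.2-fold higher number from compound 1 to compound 3 (0.06 log units; within the scatter), which is a small step. For compound 3 the estimated value is 3600 nM, with an expected range from 1700 nM to 7500 nM.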

Compound 3, solubility: 26000 nM
Beside the measured number, compound 3's estimate is 7.2-fold (0.86 log units) below it, and the stated range ends below it.
By their numbers in this assay, from the lowest: compound 1; then compound 2; then compound 3.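

In this assay, the 4-ethylphenyl position turns out to matter: replacing it with 4-methylphenyl gives an 8.4-fold higher number from compound 1 to compound 3 (0.92 log units; beyond the scatter). The change is small on paper, since only a methyl leaves, a hydrogen enters on a saturated chain carbon bound to an aromatic carbon, and no ring, hydrogen-bond donor, hydrogen-bond acceptor or net charge is involved. This settles the direction for this one pair, and the printed step is larger than the other one measured from the same starting compound, a 2.7-fold higher number from compound 1 to compound 2 (0.44 log units; beyond the scatter), so a difference of one carbon at this position can weigh at least as much as swapping hydroxy for iodo.

The data shown offer no measurement that explains the rise. From the compounds shown here alone, it remains open whether shortening ethyl to methyl would have the same effect with the iodo group of compound 2 in place of the hydroxy group, and what a longer chain such as propyl, an amine or a carboxylic acid would do on this aromatic ring.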